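Swapping the amine side chain for chloro on the shared core

The source may report more compounds than this note shows. Statements on the series, on what has been measured and on what is new or still open speak of the compounds shown alone.

Measured so far:
compound 1, `C=CCOc1ccc2c(NCCCN(C)C)ccnc2c1` — 3560 nM
compound 2, `CCOc1ccc2c(NCCCN(C)C)ccnc2c1` — 5240 nM
compound 3, `CN(C)CCNc1ccnc2cc(OCc3ccccc3)ccc12` — 2350 nM

Of the compounds shown here, three built on one core have been tested in a functional assay on RKO cells (Homo sapiens) for cytotoxicity, read by MTT assay, with a stated time of 48 h; a higher number here means a weaker inhibitor, a lower number a stronger inhibitor. Compound 1 gives 3560 nM, the second highest of the three numbers. Its nearest neighbour is compound 2, with a 1.5-fold higher number from compound 1 to compound 2 (0.17 log units; within the scatter); this step is a methyl in place of vinyl on a saturated chain carbon bound to an oxygen on an aromatic ring, and it stays within the scatter. Compound 3 gives 2350 nM, and its number and that of compound 1 lie within the scatter of each other, so nothing can be said about their order.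

Compound 4, `C=CCOc1ccc2c(Cl)ccnc2c1`, has not yet been measured. It differs from compound 1 by chloro in place of (3-(dimethylamino)propyl)amino on an aromatic carbon. Among the measured compounds shown here, the one measured step concerns the ether end of the core, not this aromatic carbon, so no measured step bears on the change. The (3-(dimethylamino)propyl)amino group, which is lost here, is shared by all three measured compounds, and nothing tested shows what the core does without it. Given that, the expectation leans toward a higher number, but with wide uncertainty. The expected step is a 4.2-fold higher number from compound 1 to compound 4 (0.62 log units; beyond the scatter). Compound 4 is expected to give roughly 15000 nM, with a range from 4000 nM to 60000 nM.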

Compound 4, half-maximal inhibitory concentration: 2460 nM
For compound 4 the middle estimate is 6.1-fold (0.79 log units) above the measured one; the measured number lies below the stated range.
By their numbers in this assay, from the lowest: compounds 3, 4, 1 and 2 (each within the scatter of the next, the first and the last beyond it).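

Putting chloro in place of (3-(dimethylamino)propyl)amino on this aromatic carbon gives a 1.4-fold lower number from compound 1 to compound 4 (0.16 log units; within the scatter) in this assay and so leaves the two compounds indistinguishable in this test. Among the compounds shown here, all the earlier compounds carried an amine side chain at this carbon, so they could not show how the core behaves without one; this pair shows that, with this ether on the core, a side chain of 7 heavy atoms with two nitrogens can give way to a single chlorine with no measurable difference in the cell result. Nothing in the data explains why the two compounds cannot be separated, and a similar number in a cell-killing test need not mean that both act in the same way.

The compounds shown leave open whether a bare hydrogen, a methoxy group or a piperazine on this same carbon would also match compound 1 or would move the number beyond the scatter. For the compounds shown here, they also leave open whether chloro can stand in for the side chain when the ether is ethyl or benzyl rather than the one in compound 1.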